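Changing the ester group of compound 1

The source may hold more compounds than are shown below. What is called first, only, known or untested is meant among the compounds shown, and "the series" means these compounds.

Measured values in an ADME assay on L6 cells (Rattus norvegicus) for cytotoxicity, read by resazurin assay, with a stated time of 70 h (on this read-out higher numbers stand for weaker inhibition and lower numbers for stronger inhibition), follow here
compound 1 `CC(=O)Oc1ccc2c(c1)C(C)=CC(C)(C)N2Cc1ccc(Cl)cc1` gives 22000 nM
compound 2 `CC(=O)Oc1ccc2c(c1)C(C)=CC(C)(C)N2Cc1cccc(Cl)c1` gives 29000 nM
compound 3 `COc1cccc(CN2c3ccc(OC(C)=O)cc3C(C)=CC2(C)C)c1` gives 29000 nM

All three sit within the scatter of one another, so compound 1 stands level with the other two. Compound 4 `COc1cc(OC)cc(C(=O)Oc2ccc3c(c2)C(C)=CC(C)(C)N3Cc2ccc(Cl)cc2)c1` differs from compound 1 by one change, 3,5-dimethoxyphenyl in place of methyl on a carbonyl carbon. Among the measured compounds shown here, the measured steps of a 1.3-fold higher number from compound 1 to compound 2 (0.12 log units; within the scatter) and a 1.3-fold higher number from compound 1 to compound 3 (0.12 log units; within the scatter) are both small, but both alter the group on a saturated chain carbon, so no measurement yet tests a change on the carbonyl carbon. In this assay no step beyond the scatter is expected, and no firm direction, giving an estimated (a 1.1-fold lower number from compound 1 to compound 4 (0.04 log units; within the scatter)). For compound 4 the estimated value is 20000 nM with an expected range from 7000 nM to 60000 nM and that range is kept wide for an untested change.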

Compound 4, half-maximal inhibitory concentration: > 190000 nM
Compound 4 was reported as a limit; the forecaster's own chance of this, stated with the estimate: 10%; middle value at least 9.5-fold (0.97 log units) away from the limit.
By their numbers in this assay, from the lowest: compounds 1, 2 and 3 (each within the scatter of the next). At a limit, above all of these: compound 4.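

In this assay, the carbonyl carbon proves far more responsive than the saturated chain carbon, whose changes all stayed within the scatter: 3,5-dimethoxyphenyl in place of methyl gives an at least 8.6-fold higher number from compound 1 to compound 4 (0.93 log units; beyond the scatter). The value of compound 4 is a limit, not a number, so the true size of this step stays unknown: the limit of > 190000 nM in this assay, at which 1 of the 4 values shown sits.

On these data alone, whether the step belongs to the aromatic ring or to its methoxy groups stays open. So does how a plain phenyl, an amine or a longer chain on the carbonyl carbon would read.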